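Changing the aryl group on the core of compound 3

A few compounds are considered here, and "the series" means these few. Any claim that something is new, unique, unknown or untested is made for them only; others in the source may bear on it.

Three compounds have been tested in a functional assay on HT-29 cells (Homo sapiens) for cytotoxicity, read by MTT assay, with a stated time of 72 h; on this read-out higher numbers stand for weaker inhibition and lower numbers for stronger inhibition:

Compound 1 `Fc1cc(Nc2cc(Nc3cccc(Cl)c3)ncn2)ccc1Oc1ccncc1-c1cccnc1`: 690 nM
Compound 2 `COc1cc(Nc2cc(Nc3ccc(Oc4ccncc4-c4cccnc4)c(F)c3)ncn2)cc(OC)c1`: 1130 nM
Compound 3 `Cn1c(=O)c(C(=O)Nc2ccc(Oc3ccncc3-c3cccnc3)c(F)c2)nn(-c2ccccc2F)c1=O`: 2100 nM

Compound 3 gives the highest of the three numbers. Its gap to compound 2 lies within the scatter, so the two cannot be ranked, while compound 1 sits beyond the scatter with a lower number. Compound 4 `Cn1c(=O)c(C(=O)Nc2ccc(Oc3ccncc3-c3cccnc3)c(F)c2)nn(-c2cccc(C(F)(F)F)c2)c1=O` differs from compound 3 by 3-(trifluoromethyl)phenyl in place of 2-fluorophenyl on an aromatic nitrogen. For the measured compounds named here, the only measured single-point step, a 1.6-fold higher number from compound 1 to compound 2 (0.21 log units; within the scatter), also swaps one aryl group for another, but on a different nitrogen of a different core, and it stayed within the scatter; it is therefore only a loose guide. The expected step of a 1.1-fold lower number from compound 3 to compound 4 (0.02 log units; within the scatter) is accordingly small, with no clear direction. Compound 4 is estimated at 2000 nM, within a range from 700 nM to 6000 nM.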

Compound 4, half-maximal inhibitory concentration: 510 nM
For compound 4 the middle estimate is 3.9-fold (0.59 log units) above the measured one; measured number outside the range, below it.
By their numbers in this assay, from the lowest: compounds 4, 1, 2 and 3 (each within the scatter of the next, the first and the last beyond it).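

On this core, the aryl group on the aromatic nitrogen clearly affects the read-out: 3-(trifluoromethyl)phenyl in place of 2-fluorophenyl gives a 4.1-fold lower number from compound 3 to compound 4 (0.61 log units; beyond the scatter), whereas the earlier aryl swap on a different core, a 1.6-fold higher number from compound 1 to compound 2 (0.21 log units; within the scatter), stayed within the scatter. No measurement available here explains this step.

Because the group and its place on the phenyl ring change together, the two contributions cannot be separated. Also open, going by these compounds, is how a phenyl ring carrying an amine or a carboxylic acid would behave at this position.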